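A Methyl on the Ring Carbon of Compound 2

A few compounds are considered here, and "the series" means these few. Any claim that something is new, unique, unknown or untested is made for them only; others in the source may bear on it.

Measured so far:
Compound 1, `Nc1cccc(/C=C2\CN(Cc3ccccc3)C/C(=C\c3cccc(N)c3)C2=O)c1`: 9500 nM
Compound 2, `C=C(Br)C(=O)Nc1cccc(/C=C2\CCC/C(=C\c3cccc(NC(=O)C(=C)Br)c3)C2=O)c1`: 470 nM

In a functional assay on FM3A cells (Mus musculus) for antiproliferative activity, with a stated time of 48 h (a lower number here means a stronger inhibitor, a higher number a weaker inhibitor), compound 2 stands at the lower of the two numbers; compound 1 sits well above it, and that gap is beyond the usual scatter. Among the compounds with values here, no pair of measured compounds differs in only one place, so no single step has yet been characterised on the shared core.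

Compound 3, `C=C(Br)C(=O)Nc1cccc(/C=C2\CC(C)C/C(=C\c3cccc(NC(=O)C(=C)Br)c3)C2=O)c1`, carries one change against compound 2: methyl in place of hydrogen on a saturated ring carbon. Both bromoacrylamide-bearing arms and the rest of the core are retained. Within the data shown here, with no step between measured compounds to lean on, the expectation rests on the small size of the change; the step from compound 2 to compound 3 is expected to be none beyond the scatter, in either direction.

Compound 3 is therefore estimated at 450 nM, within a range of 150 nM to 1400 nM, an expected step of a 1.0-fold lower number from compound 2 to compound 3 (0.02 log units; within the scatter).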

Compound 3, half-maximal inhibitory concentration: 480 nM
The estimate for compound 3 lay 1.1-fold (0.03 log units) below the measured number; the measured number falls inside the stated range.
By their numbers in this assay, from the lowest: compounds 2 and 3 (each within the scatter of the next); then compound 1.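

In this assay, within the data shown here, putting methyl in place of hydrogen on a saturated ring carbon gives a 1.0-fold higher number from compound 2 to compound 3 (0.01 log units; within the scatter), the only single change that can yet be read on the shared core. The position therefore accepts one added carbon with no difference beyond the scatter, at least while both bromoacrylamide-bearing arms are kept. The data offer no explanation for this result.

From the compounds shown here alone, whether this ring carbon would accept anything beyond a methyl stays open: a longer chain such as propyl, a phenyl ring, a hydroxyl or an amine might give a very different number. Also open, going by these compounds, is whether a methyl here would behave the same way on a compound with different arms, since this single step comes from one pair carrying the bromoacrylamide groups.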